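Chain-extended coumarin ether: methyl replacing chloro on the aryloxy ring

The source may hold more compounds than are shown below. What is called first, only, known or untested is meant among the compounds shown, and "the series" means these compounds.

The series comprises three compounds that share a coumarin ether core joined through an imine to a pyrazole bearing an aryloxy group. Compound 1 `Cc1ccc(Oc2c(/C=N\CCCCCOc3cc4oc(=O)cc(C)c4cc3Cl)c(C)nn2C)cc1` carries a five-carbon chain and a methyl on the aryloxy ring; compound 2 `Cc1nn(C)c(Oc2ccc(Cl)cc2)c1/C=N\CCCCCCOc1cc2oc(=O)cc(C)c2cc1Cl` carries a six-carbon chain and a chloro. In a functional assay on SMMC-7721 cells (Homo sapiens) for antiproliferative activity, read by MTT assay, with a stated time of 72 h (on this read-out lower numbers stand for stronger inhibition and higher numbers for weaker inhibition), compound 1 gives 11100 nM, and in this assay compound 2 gives 2080 nM, the lower of the two numbers, with a gap beyond the scatter. Compound 2 therefore stands at the lower end of the numbers seen so far.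

Compound 3 `Cc1ccc(Oc2c(/C=N\CCCCCCOc3cc4oc(=O)cc(C)c4cc3Cl)c(C)nn2C)cc1` keeps the six-carbon chain of compound 2 but differs in one place: methyl in place of chloro on an aromatic carbon. Going by the values given here, no single-change step between measured compounds is known, so the size of this step cannot be read off directly. The two measured values show that the combination of a shorter chain and the methyl in place of chloro gives the higher number, and part of that gap may belong to the methyl. Compound 3 is therefore expected to give a somewhat higher number than compound 2, a modest step of a 1.9-fold higher number from compound 2 to compound 3 (0.28 log units; within the scatter) that may or may not exceed the scatter. For compound 3 in this assay the estimate is 4000 nM, with a range from 1500 nM to 11000 nM.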

Compound 3, half-maximal inhibitory concentration: 18600 nM
Estimate against measurement, compound 3: 4.7-fold (0.67 log units) below; the measured number lies above the stated range.
By their numbers in this assay, from the lowest: compound 2; then compounds 1 and 3 (each within the scatter of the next).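

In this assay, the change from 4-chlorophenoxy to 4-methylphenoxy, now seen with the chain held constant, gives an 8.9-fold higher number from compound 2 to compound 3 (0.95 log units; beyond the scatter), so this single exchange at the position para to a large group is enough to move the number beyond the scatter. With methyl in place, compound 1 at 11100 nM and compound 3 at 18600 nM lie within the scatter of each other, so the difference in chain length between them does not separate their numbers. The data offer nothing that explains the effect of this exchange.

As far as these compounds go, whether a bromo or a methoxy group at this place would read like chloro or like methyl remains open. So does the effect of a longer chain, and of any change in chain length with chloro in place.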